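A few compounds are considered here, and "the series" means these few. Any claim that something is new, unique, unknown or untested is made for them only; others in the source may bear on it.

Of the compounds shown here, three have been measured so far in a functional assay on HL-60 cells (Homo sapiens) for cytotoxicity, read by MTT assay, with a stated time of 48 h (on this read-out higher numbers stand for weaker inhibition and lower numbers for stronger inhibition), on this series. Compound 1 (`COc1ccc(-c2c[nH]c(=O)n2-c2cc(OC)c(OC)c(OC)c2)cc1[N+](=O)[O-]`) gives 14300 nM in this test, and compound 2 (`COc1ccc(-c2c[nH]c(=O)n2-c2cc(OC)c(OC)c(OC)c2)cc1N`) gives 10300 nM in the same test. Compound 3 (`COc1cc(-n2c(-c3ccccc3)cn(C(C)=O)c2=O)cc(OC)c1OC`) gives 5600 nM here. Within the data shown here, that number is clearly lower than the one for compound 1, but it lies within the usual scatter of the one for compound 2.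

The next compound, compound 4 (`COc1cc(-n2c(-c3ccc(F)cc3F)cn(C(C)=O)c2=O)cc(OC)c1OC`), is compound 3 with 2,4-difluorophenyl in place of phenyl on an aromatic carbon of the five-membered aromatic ring (2,4-difluorophenyl in place of phenyl on an aromatic carbon). Among the measured compounds shown here, no measured compound carries fluorine, so nothing yet shows directly what this exchange does. For the measured compounds named here, the only measured step between two close relatives (a 1.4-fold lower number from compound 1 to compound 2 (0.14 log units; within the scatter)) swaps nitro for amino on a different compound pair, and it stays within the scatter. Going by the values given here, with that small step from compound 1 as the sole and indirect guide, no step beyond the scatter is expected in this assay in either direction. The expected change (a 1.1-fold lower number from compound 3 to compound 4 (0.05 log units; within the scatter)) is therefore small and remains an estimate with wide uncertainty. Compound 4 is estimated at 5000 nM with an expected range from 1800 nM to 14000 nM in this test.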

Compound 4, half-maximal inhibitory concentration: 7600 nM
Compound 4: middle estimate off by 1.5-fold (0.18 log units), on the low side; the range from low to high includes it.
By their numbers in this assay, from the lowest: compounds 3, 4, 2 and 1 (each within the scatter of the next, the first and the last beyond it).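

Among these compounds, the exchange of phenyl for 2,4-difluorophenyl gives the first direct reading at this aromatic carbon of the five-membered ring in this assay: a 1.4-fold higher number from compound 3 to compound 4 (0.13 log units; within the scatter), so compound 3 and compound 4 cannot be told apart on this read-out. The earlier compounds could not show this, as none of them carries fluorine and their only listed step, the swap of nitro for amino, lies at a different place on a different pair. Here, adding two fluorine atoms to the phenyl ring, on a compound that also bears an acetyl group, leaves the number within the usual scatter, and no supporting measurement is available to explain this result.

Going by these compounds, it remains open whether a different group on that phenyl ring, such as a carboxylic acid or a single chlorine atom, would move the number beyond the scatter, as one fluorine-bearing example says little about other replacements. No pair shown differs only in the acetyl group, so its contribution to these numbers also remains unknown.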